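The compounds below may be only part of what the source reports. "The series", "measured", "known", "first", "only" and "open" are said of these compounds alone.

Measured so far:
compound 1, `COc1ccc(/C=C/C(=O)C(=Cc2ccc(O)cc2)C(=O)/C=C/c2ccc(OC)c(OC)c2)cc1OC` — 420 nM
compound 2, `COc1ccc(/C=C/C(=O)C(=Cc2cccc(OC)c2OC)C(=O)/C=C/c2ccc(OC)c(OC)c2)cc1OC` — 670 nM

Both compounds were tested in a functional assay on A549 cells (Homo sapiens) for inhibition, read by sulforhodamine B assay, with a stated time of 48 h; on this read-out lower numbers stand for stronger inhibition of growth and higher numbers for weaker inhibition of growth. Compound 1 gives 420 nM and compound 2 gives 670 nM. Within the data shown here, the one step measured, a 1.6-fold higher number from compound 1 to compound 2 (0.20 log units; within the scatter), is within the usual scatter, so compound 2 holds the higher of the two numbers without being separated from compound 1 in any reliable way.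

Compound 3, `COc1ccc(/C=C/C(=O)C(=Cc2ccc(C)o2)C(=O)/C=C/c2ccc(OC)c(OC)c2)cc1OC`, has not been measured in this assay. It differs from compound 2 in one place: 5-methylfuran-2-yl in place of 2,3-dimethoxyphenyl on a double-bonded chain carbon bound to a double-bonded chain carbon. Among the measured compounds shown here, the only measured step on that same chain carbon exchanged 4-hydroxyphenyl for 2,3-dimethoxyphenyl and stayed within the scatter. The change to compound 3 is of a different kind, exchanging a six-membered aromatic ring of carbon only for a five-membered aromatic ring with 1 hetero atom, and nothing measured here shows how such an exchange plays out. For the measured compounds named here, with the shared core unchanged and the one known step small, the expected step of a 1.0-fold higher number from compound 2 to compound 3 (0.02 log units; within the scatter) is also small, with no clear direction. Compound 3 is estimated at 700 nM, in a range from 250 nM to 2000 nM.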

Compound 3, concentration for 50% growth inhibition: 1310 nM
For compound 3 the middle estimate is 1.9-fold (0.27 log units) below the measured one, within the range that was stated.
By their numbers in this assay, from the lowest: compounds 1, 2 and 3 (each within the scatter of the next, the first and the last beyond it).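

In this assay the place on a double-bonded chain carbon bound to a double-bonded chain carbon now holds a five-membered aromatic ring with 1 hetero atom, and a 2.0-fold higher number from compound 2 to compound 3 (0.29 log units; within the scatter) shows that 5-methylfuran-2-yl cannot be told apart from 2,3-dimethoxyphenyl there. Set against 4-hydroxyphenyl, the same group gives a 3.1-fold higher number from compound 1 to compound 3 (0.49 log units; beyond the scatter) and this modest step is the only one at this place that lies beyond the scatter, so the place does respond to what sits on it, though the response so far is small and compound 2 cannot be separated from either of the other two. No accompanying measurement bears on why compound 3 and compound 1 differ.

Going by these compounds, all three groups at this place are aromatic rings, so it remains open how a saturated ring such as piperidine, an amine or a longer alkyl chain would behave on the same chain carbon. A plain furan-2-yl group without the methyl is also absent from the compounds shown, which leaves the contribution of that methyl unknown.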